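Swapping vinyl for 2-hydroxyethyl on a sulfonyl chain

This account rests on a few compounds, and the source may have more. Where it says the series, first, only, none or still open, it means among the compounds named here.

Measured compounds
compound 1 `C=CCCCCCCS(=O)(=O)/C=C/c1ccc(O)c(O)c1` gives 6400 nM
compound 2 `O=S(=O)(/C=C/c1ccc(O)c(O)c1)CC1CCCCC1` gives 7500 nM
compound 3 `O=S(=O)(/C=C/c1ccc(O)c(O)c1)CC1CC1` gives 10500 nM

In a functional assay, read by fluorescence and spectrophotometry, with a stated time of 1 h (on this read-out higher numbers stand for an effect only at larger amounts of compound and lower numbers for an effect already at smaller amounts), the three values lie within the usual scatter of one another, so compound 1 cannot be ranked apart from compound 2 or compound 3. The unmeasured compound 4 `O=S(=O)(/C=C/c1ccc(O)c(O)c1)CCCCCCCCO` keeps the core of compound 1 and changes in one place. The change is 2-hydroxyethyl in place of vinyl on a saturated chain carbon, six bonds along the chain from a sulfonyl sulfur and in short it puts 2-hydroxyethyl in place of vinyl on a saturated chain carbon, six bonds along the chain from a sulfonyl sulfur.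

The closest evidence comes from the swaps of the group carried on this chain. They gave a 1.2-fold higher number from compound 1 to compound 2 (0.07 log units; within the scatter) and a 1.6-fold higher number from compound 1 to compound 3 (0.22 log units; within the scatter) and a 1.4-fold higher number from compound 2 to compound 3 (0.15 log units; within the scatter) as their steps, all of them small. None of the three compounds carries a 2-hydroxyethyl group, so this evidence is only indirect. With compound 2 and compound 3 as the guide, no step beyond the scatter is expected, and no firm direction can be given. The expected step is a 1.3-fold higher number from compound 1 to compound 4 (0.10 log units; within the scatter) as a best guess. In this assay compound 4 is estimated at 8000 nM with a range from 4000 nM to 16000 nM around that middle.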

Compound 4, half-maximal effective concentration: 6700 nM
The estimate for compound 4 lay 1.2-fold (0.08 log units) above the measured number, and the stated range covers the measured number.
By their numbers in this assay, from the lowest: compounds 1, 4, 2 and 3 (each within the scatter of the next).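

In this assay, putting 2-hydroxyethyl in place of vinyl on a saturated chain carbon, six bonds along the chain from a sulfonyl sulfur, gives a 1.0-fold higher number from compound 1 to compound 4 (0.02 log units; within the scatter), so this swap leaves the number within the scatter. The earlier compounds shown here varied this part of the molecule only among groups of carbon and hydrogen, whereas compound 4 shows that a group with an oxygen, bringing 1 hydrogen-bond donor and 1 hydrogen-bond acceptor, can sit at this position with no step beyond the scatter in this read-out. No supporting measurement is available to explain why the number stays so close.

The compounds shown leave open whether an amine or a carboxylic acid at this chain end would also stay within the scatter, or would be the first group here to produce a clear step. They also leave open how the same hydroxyl group would read on a much shorter or a longer chain, and so whether its place along the chain matters at all.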